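Replacing chloro with a methanesulfonamidomethyl group on the aryl ring

This account rests on a few compounds, and the source may have more. Where it says the series, first, only, none or still open, it means among the compounds named here.

Measured compounds:
compound 1 `Cn1nc2c(=O)n(CC3(O)CCN(Cc4ccc(-c5ccco5)cc4Cl)CC3)cnc2c1-c1ccc(CNC(=O)C(F)(F)F)cc1`, an assay on isolated protein for inhibition of ubiquitin carboxyl-terminal hydrolase 7 (Homo sapiens), with stated times of 30 min and 2 h; on this read-out lower numbers stand for stronger inhibition and higher numbers for weaker inhibition: 2060 nM
compound 2 `Cn1nc2c(=O)n(CC3(O)CCN(Cc4ccc(-c5ccco5)cc4Cl)CC3)cnc2c1-c1ccc(C2(N)CC2)cc1`, this assay: 66.1 nM
compound 3 `Cn1nc2c(=O)n(CC3(O)CCN(Cc4ccc(-c5ccco5)cc4Cl)CC3)cnc2c1-c1ccc(Cl)cc1`, this assay: 143 nM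

Compound 3 stands second highest of the three numbers; the nearest step to it is a 2.2-fold higher number from compound 2 to compound 3 (0.34 log units; beyond the scatter), the furthest is a 14-fold lower number from compound 1 to compound 3 (1.16 log units; beyond the scatter).

Compound 4 `Cn1nc2c(=O)n(CC3(O)CCN(Cc4ccc(-c5ccco5)cc4Cl)CC3)cnc2c1-c1ccc(CNS(C)(=O)=O)cc1` differs from compound 3 in one place: (methanesulfonamido)methyl in place of chloro on an aromatic carbon. Among the compounds with values here, the step that bears most on this change is the one between compound 1 and compound 3, since compound 1 also carries a substituted aminomethyl group at that position, and there the move to chloro gave a 14-fold lower number from compound 1 to compound 3 (1.16 log units; beyond the scatter). The present change runs in the opposite direction, from chloro to a substituted aminomethyl group, so a large rise in the number is expected for compound 4, though the two groups entering are not the same and the size is uncertain. The expected step is an 8.4-fold higher number from compound 3 to compound 4 (0.92 log units; beyond the scatter). Compound 4 is therefore estimated at 1200 nM in this assay, within a range from 400 nM to 4000 nM.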

Compound 4, half-maximal inhibitory concentration: 65.3 nM
Compound 4: the middle estimate sits 18-fold (1.26 log units) above what was measured; measured number below the stated range.
By their numbers in this assay, from the lowest: compounds 4 and 2 (each within the scatter of the next); then compound 3; then compound 1.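

In this assay, a substituted aminomethyl group at this position, para to a large group, carries no penalty of its own: (methanesulfonamido)methyl in place of chloro gives a 2.2-fold lower number from compound 3 to compound 4 (0.34 log units; beyond the scatter) and so does not raise the number. The weak result for compound 1 therefore traces to what sits on the amine nitrogen, since methylsulfonyl in place of (trifluoromethyl)carbonyl gives a 32-fold lower number from compound 1 to compound 4 (1.50 log units; beyond the scatter) on an otherwise unchanged structure. The step to the (methanesulfonamido)methyl group from 1-aminocyclopropyl, a 1.0-fold lower number from compound 2 to compound 4 (0.01 log units; within the scatter), shows that two quite different groups can serve equally well here.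

The data give no reason for the gap between the two groups on that nitrogen. Also open, on these data alone, is whether the sulfonyl is needed at all, which a free aminomethyl group, an acetamidomethyl group or an ethanesulfonamidomethyl group would help to settle.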